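Naphthalenyl carbonyl in place of a difluorophenyl carbonyl

The source may hold more compounds than are shown below. What is called first, only, known or untested is meant among the compounds shown, and "the series" means these compounds.

Of the compounds shown here, three sharing one core have been tested in an ADME assay on MT4 cells (Homo sapiens) for cytotoxicity, read by MTT assay; a higher number here means that more compound is tolerated, a lower number that less compound is tolerated. Compound 2 `O=C1c2ccccc2C(=O)N1CCOC(=S)N(C(=O)c1ccc(F)c(F)c1)c1ccc(Cl)cc1` gives 52000 nM. Compound 3 `Cc1ccc(N(C(=O)c2cc(F)cc(F)c2)C(=S)OCCN2C(=O)c3ccccc3C2=O)cc1` gives 54000 nM, which lies within the scatter of the number for compound 2, so the two cannot be ordered. Compound 1 `Cc1ccc(N(C(=O)c2ccccc2C)C(=S)OCCN2C(=O)c3ccccc3C2=O)cc1` reaches only the limit of the assay, > 100000 nM, and no number is known for it. For the measured compounds named here, the one step between measured compounds, an at least 1.8-fold lower number from compound 1 to compound 3 (0.26 log units; that floor lies within the scatter), is the sole guide to what a change at the carbonyl carbon does. Compound 4 `O=C1c2ccccc2C(=O)N1CCOC(=S)N(C(=O)c1ccc2ccccc2c1)c1ccc(Cl)cc1` is not yet measured; it differs from compound 2 by naphthalen-2-yl in place of 3,4-difluorophenyl on a carbonyl carbon. Going by the values given here, no measured step exchanges a difluorophenyl for a naphthalenyl group, and the one step at this carbonyl carbon did not clearly move the number, so only a small change is expected, leaning toward a somewhat lower number. Compound 4 is therefore estimated at 40000 nM, between 15000 nM and 100000 nM. That estimate would mean a step of a 1.3-fold lower number from compound 2 to compound 4 (0.11 log units; within the scatter), which is expected to remain within the usual scatter.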

Compound 4, half-maximal cytotoxic concentration: 37000 nM
For compound 4 the middle estimate is 1.1-fold (0.03 log units) above the measured one; the range from low to high includes it.
By their numbers in this assay, from the lowest: compounds 4, 2 and 3 (each within the scatter of the next). At a limit, above all of these: compound 1.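

For the compounds shown here, compound 1 stands at a limit, so the one earlier step at this carbonyl carbon fixed only a floor: the limit of > 100000 nM in this assay, at which 1 of the 4 values shown sits. In this assay, naphthalen-2-yl in place of 3,4-difluorophenyl has a number at both ends and gives a 1.4-fold lower number from compound 2 to compound 4 (0.15 log units; within the scatter). This place therefore carries a group of 2 six-membered aromatic rings and no fluorine with a number that cannot be told apart from that of the difluorophenyl group.

Every group shown on this carbonyl carbon is an aromatic ring of carbon only, and whether an amine, a carboxylic acid or a longer alkyl chain there would move the number beyond the scatter stays open. Also open, going by these compounds, is whether the same exchange would read alike on the core of compound 3.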